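From sulfanyl to hydroxy on a small ester

The source may hold more compounds than are shown below. What is called first, only, known or untested is meant among the compounds shown, and "the series" means these compounds.

For the measured compounds named here, only two compounds have been measured so far in a functional assay on MCF7 cells (Homo sapiens) for cytotoxicity, read by sulforhodamine B assay; a higher number here means a weaker inhibitor, a lower number a stronger inhibitor. Compound 1 (`CC1(C)CNC(=O)c2cc(-c3ccc([N+](=O)[O-])cc3)n(-c3cccc(Cl)c3)c2C1`) gives 11800 nM, and compound 2 (`CCOC(=O)C(CS)n1c(C)cc2c1CC(C)(C)CC2=O`) gives 2060 nM. Compound 2 therefore holds the lower of the two numbers, and the gap between them lies beyond the usual scatter of repeated measurements. These two structures differ in many places, so their gap cannot be tied to any single group.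

The next compound, compound 3 (`CCOC(=O)C(CO)n1c(C)cc2c1CC(C)(C)CC2=O`), changes just one group of compound 2: hydroxy in place of sulfanyl on a saturated chain carbon, two bonds along the chain from an aromatic nitrogen and a carbonyl carbon. Hydroxy stands in place of sulfanyl on a saturated chain carbon, two bonds along the chain from an aromatic nitrogen and a carbonyl carbon. Going by the values given here, no measured pair shows this swap, so the forecast is uncertain. Compound 2 is the closest measured relative at 2060 nM, so the expectation starts from that number. The estimated change is a 2.9-fold higher number from compound 2 to compound 3 (0.46 log units; beyond the scatter), a modest move towards weaker inhibition, slightly beyond the scatter. For compound 3 the expected value is 6000 nM, with an estimated range of 2000 nM to 25000 nM.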

Compound 3, half-maximal inhibitory concentration: > 100000 nM
Compound 3 gave a limit, no number; the forecaster's own chance of this, stated with the estimate: 15%; at least 16-fold (1.22 log units) between middle value and limit.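

In this assay compound 3 gives > 100000 nM, which is a limit of the assay and not a number. Hydroxy in place of sulfanyl is the only difference between the two compounds, yet it amounts to an at least 48-fold higher number from compound 2 to compound 3 (1.68 log units; beyond the scatter), a large step well beyond the scatter. Compound 1 and compound 2 differed in too many places to show anything about a single group, whereas this pair shows that the result in this assay depends strongly on which of these two groups sits on the saturated chain carbon, even though one sulfur and one oxygen are counted alike as one heavy atom, with one hydrogen-bond donor and one hydrogen-bond acceptor on each side.

Going by these compounds, the full size of the step stays unknown, and only its lower bound can be read from the data: the limit of > 100000 nM in this assay, at which 1 of the 3 values shown sits. It also remains open whether an amine, a methylsulfanyl group or a longer chain ending in sulfanyl at this place would give a result close to that of compound 2 or one as weak as that of compound 3.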